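This account rests on a few compounds, and the source may have more. Where it says the series, first, only, none or still open, it means among the compounds named here.

In a functional assay on RT-112 cells (Homo sapiens) for antiproliferative activity, read by MTT assay, with a stated time of 72 h (a lower number here means a stronger inhibitor of growth, a higher number a weaker inhibitor of growth), compound 1 `COc1cc(Nc2ncnc3c(NC(=O)Nc4cc(F)cc(F)c4)cccc23)cc(OC)c1` gives 2630 nM and compound 2 `COc1cc(Nc2ncnc3c(NC(=O)Nc4ccc(Cl)cc4Cl)cccc23)cc(OC)c1` gives 3060 nM, so compound 2 stands level with compound 1. Compound 3 `COc1cc(Nc2ncnc3c(NC(=O)Nc4ccc(C(F)(F)F)cc4Cl)cccc23)cc(OC)c1` keeps the shared core and differs from compound 2 in one place: trifluoromethyl in place of chloro on an aromatic carbon. Among the compounds with values here, the one measured step that bears on this replaced 3,5-difluorophenyl with 2,4-dichlorophenyl and gave a 1.2-fold higher number from compound 1 to compound 2 (0.07 log units; within the scatter), which lies within the scatter. Within the data shown here, with only that step as a guide, no shift beyond the scatter is expected in this assay, and the expected step is a 1.0-fold lower number from compound 2 to compound 3 (0.01 log units; within the scatter). Compound 3 is therefore estimated at 3000 nM, with a range of 1300 nM to 7000 nM.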

Compound 3, concentration for 50% growth inhibition: 1080 nM
Compound 3: middle estimate off by 2.8-fold (0.44 log units), on the high side; the measured number lies below the stated range.
By their numbers in this assay, from the lowest: compound 3; then compounds 1 and 2 (each within the scatter of the next).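

At the position para to a large group, trifluoromethyl in place of chloro moves the number beyond the scatter in this assay (a 2.8-fold lower number from compound 2 to compound 3 (0.45 log units; beyond the scatter)), which the earlier step between compound 1 and compound 2 did not do. The 2-chloro-4-(trifluoromethyl)phenyl group on the amide-type nitrogen also stands apart from 3,5-difluorophenyl (a 2.4-fold lower number from compound 1 to compound 3 (0.39 log units; beyond the scatter)). No measurement shown here accounts for this shift.

Going by these compounds, whether a nitrile or an amine at this position would give a lower or a higher number stays open. So does whether trifluoromethyl would have the same effect without the chloro group on that ring.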